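Trimming an Ethyl to Methyl on an Adenosine Ligand

The source may hold more compounds than are shown below. What is called first, only, known or untested is meant among the compounds shown, and "the series" means these compounds.

Compound 2 `CCn1c(-c2ccccc2)nc2c(NC3CCOC3)ncnc21` gives 10 nM in an assay on CHO cells for displacement of a labelled ligand from adenosine receptor A1 (Homo sapiens), read by scintillation counting, with a stated time of 3 h (on this read-out higher numbers stand for weaker inhibition and lower numbers for stronger inhibition), the highest of the two numbers recorded, while compound 1 `Cn1c(-c2ccccc2)nc2c(NC3CCCCC3)ncnc21` gives 5.7 nM in this assay, a gap that lies within the scatter of repeated measurements. Compound 3 `Cn1c(-c2ccccc2)nc2c(NC3CCOC3)ncnc21` differs from compound 2 by hydrogen in place of methyl on a saturated chain carbon bound to an aromatic nitrogen, which read one bond further out is ethyl to methyl. Among the compounds with values here, no measured pair shows this change alone, so the step is expected to stay within the scatter, with no clear direction. Compound 3 is therefore estimated at 8 nM, with a likely range from 3 nM to 25 nM. The expected step of a 1.3-fold lower number from compound 2 to compound 3 (0.10 log units; within the scatter) is small.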

Compound 3, inhibition constant: 8 nM
Beside the measured number, compound 3's estimate shows no gap at the digits printed; the range from low to high includes it.
By their numbers in this assay, from the lowest: compounds 1, 3 and 2 (each within the scatter of the next).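

In this assay, within the data shown here, hydrogen in place of methyl on a saturated chain carbon bound to an aromatic nitrogen gives a 1.3-fold lower number from compound 2 to compound 3 (0.10 log units; within the scatter), the first measured pair to isolate this change. Oxolan-3-yl in place of cyclohexyl on a nitrogen on an aromatic ring gives a 1.4-fold higher number from compound 1 to compound 3 (0.15 log units; within the scatter), so neither place shows a clear shift for its change. No evidence is available to explain these results. The compounds shown leave open whether a longer chain in place of the ethyl, or a piperidin-4-yl group in place of the oxolan-3-yl, would also stay within the scatter.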